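The source may hold more compounds than are shown below. What is called first, only, known or untested is meant among the compounds shown, and "the series" means these compounds.

Measured compounds so far:
compound 1 `Cc1ccc(S(=O)(=O)N[C@@H](CC(=O)NC(C)(C)C)C(=O)NCCNC(=O)c2cc(Cl)ccn2)cc1`, in an ADME assay on Karpas-1106P cells (Homo sapiens) for cytotoxicity; on this read-out lower numbers stand for an effect already at smaller amounts and higher numbers for an effect only at larger amounts of compound: > 11100 nM, a limit of the assay rather than a number
compound 2 `COc1cccc(C(=O)NCCNC(=O)[C@H](CC(=O)NC(C)(C)C)NS(=O)(=O)c2ccc(C)cc2)c1`, in this assay: > 11100 nM, likewise a limit of the assay

Compound 1 therefore has no numerical value in this assay; it sits at the limit of > 11100 nM in this assay, at which 2 of the 2 values shown sit, as does every value shown. Going by the values given here, the one measured step, a step that the two limits leave unreadable from compound 1 to compound 2, exchanges the group on the carbonyl carbon, yet its size cannot be read, because both ends are limits.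

Compound 3 `Cc1ccc(S(=O)(=O)N[C@@H](CC(=O)NC(C)(C)C)C(=O)NCCNC(=O)c2ccccc2Cl)cc1` differs from compound 1 in the same place: 2-chlorophenyl in place of 4-chloropyridin-2-yl on a carbonyl carbon. Among the compounds with values here, since the only comparable step gives no readable size or direction, nothing in the data points to compound 3 leaving the region of the limit. Compound 3 is therefore expected to give about 20000 nM, estimated between 8000 nM and 60000 nM. The expected step is a step that the limit leaves unreadable from compound 1 to compound 3, most likely again reported as a limit.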

Compound 3, half-maximal effective concentration: > 11100 nM
Compound 3 was reported as a limit; the forecaster's own chance of this, stated with the estimate: 85%; the middle value is on the limit's open side.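

Compound 3 gives no readable step from compound 1 or compound 2, since all three compounds end at the same limit rather than at a number: the limit of > 11100 nM in this assay, at which 3 of the 3 values shown sit.

Still open, going by these compounds, is how much of any of the three compounds is needed for an effect in this assay, and whether the group on the carbonyl carbon alters that amount at all.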